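The compounds below may be only part of what the source reports. "The series", "measured", "known", "first", "only" and "open" are said of these compounds alone.

Compound 1 has the structure `CCOC(=O)Cn1ncc2c(Nc3ccc(NS(=O)(=O)c4ccccc4)cc3)ncnc21`. In a functional assay on cells (Homo sapiens) for inhibition, read by MTT assay, with a stated time of 72 h (on this read-out lower numbers stand for stronger inhibition and higher numbers for weaker inhibition), compound 1 gives > 100 ug/mL, which is a limit of the assay rather than a measured number. Two further compounds sit at the same point. Compound 2, `O=C(O)Cn1ncc2c(Nc3ccc(NC(=O)CCl)cc3)ncnc21`, gives in this assay a value of > 100 ug/mL, again a limit. Compound 3, `CCOC(=O)Cn1ncc2c(Cl)ncnc21`, gives in this assay a value of > 100 ug/mL, also a limit. All three values therefore rest at the limit of > 100 ug/mL in this assay, at which 3 of the 3 values shown sit, so compound 1 stands level with every other compound shown, and no step between measured compounds can be drawn from them.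

Compound 4, `CCOC(=O)Cn1ncc2c(Nc3ccc(NS(=O)(=O)c4ccc(Br)cc4)cc3)ncnc21`, differs from compound 1 in one place: bromo in place of hydrogen on an aromatic carbon. Among the compounds with values here, because every value shown sits at the limit of > 100 ug/mL in this assay, at which 3 of the 3 values shown sit, there is no measured step to lean on, and the change is small. The step that the limit leaves unreadable from compound 1 to compound 4 is expected to be none beyond the scatter. Compound 4 is expected to give 150 ug/mL in this assay, with a likely range from 40 ug/mL to 500 ug/mL.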

Compound 4, half-maximal inhibitory concentration: > 64 ug/mL
Compound 4: only a limit was reported; the forecaster's own chance of this, stated with the estimate: 80%; the middle value lies beyond the limit too.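

Within the data shown here, compound 1 and compound 4 are both reported in this assay only as limits, not as numbers, so no step between them can be read. The compounds shown leave open how strongly any of them inhibits, and whether the bromo group changes that at all.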